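Swapping phenyl for tert-butyl on a ketone carbonyl

The source may report more compounds than this note shows. Statements on the series, on what has been measured and on what is new or still open speak of the compounds shown alone.

Measured compounds:
Compound 1 `O=C1CCCc2[nH]c(=O)c(C(=O)c3ccccc3)cc21`: 0%
Compound 2 `O=C1CC(c2ccccc2)Cc2[nH]c(=O)c(C(=O)c3ccccc3)cc21`: 0%

In an assay on isolated protein for inhibition of 3',5'-cyclic-AMP phosphodiesterase 4A (Cavia porcellus), read by cAMP accumulation, tested at 1 uM (a lower number here means a weaker effect, a higher number a stronger effect of the compound at the concentration tested), compound 1 gives 0%. Compound 2 gives 0% in the same test, so compound 1 stands level with compound 2 at the digits shown, and the only measured step, no change at the digits printed from compound 1 to compound 2 (within the scatter), tells that putting phenyl in place of hydrogen on a saturated ring carbon leaves the read-out where it was.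

Compound 3 `CC(C)(C)C(=O)c1cc2c([nH]c1=O)CCCC2=O` differs from compound 1 at another place: tert-butyl in place of phenyl on a carbonyl carbon. Going by the values given here, no measured step touches the carbonyl carbon, so the step from compound 1 to compound 2 bears on it only loosely, showing that the shared core tolerates one change without any shift in this assay. The two measured values are both at the floor of the read-out, and nothing here points to a rise. The expected step is therefore a number 3 percentage points higher from compound 1 to compound 3 (within the scatter), none beyond the scatter. Compound 3 is thus expected to give 3% in this assay, with a range from 0% to 18%.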

Compound 3, a percentage reported as inhibition, at one concentration (the size of the read-out at that concentration, not a potency): 0%
Estimate against measurement, compound 3: 3 percentage points above; low and high end bracket the measured number.
By their numbers in this assay, from the lowest: compounds 1, 2 and 3 (each within the scatter of the next).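

In this assay, tert-butyl in place of phenyl on the carbonyl carbon gives no change at the digits printed from compound 1 to compound 3 (within the scatter). Going by these compounds alone, this is the first measured change at this position, and it shows that the aromatic ring on the carbonyl carbon can be exchanged for a group with no ring without lifting the read-out from the level of compound 1, 0%. Together with the earlier step at the saturated ring carbon, no change at the digits printed from compound 1 to compound 2 (within the scatter), it means that changes at two different places on the shared core have now left the read-out unmoved. No measurement shown here speaks to why the read-out stays where it does.

From the compounds shown here alone, with every read-out at this level at a single tested concentration, the phenyl and tert-butyl groups cannot be ranked against each other, so how much this position matters remains unknown. Going by these compounds, it also remains open whether an amine or a carboxylic acid on the carbonyl carbon, or a longer chain on the saturated ring carbon, would move the read-out at all.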